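Chloro to nitro on two related cores in a cytotoxicity assay

The source may report more compounds than this note shows. Statements on the series, on what has been measured and on what is new or still open speak of the compounds shown alone.

Of the compounds shown here, three have been measured in a functional assay on Bel-7402 cells (Homo sapiens) for cytotoxicity, read by MTT assay, with a stated time of 48 h; a higher number here means a weaker inhibitor, a lower number a stronger inhibitor. Compound 1 `CCn1cc(-c2nc3ccc(Cl)cc3[nH]2)c(=O)c2cc(F)c(N3CCNCC3)nc21` gives 21500 nM, the highest of the three numbers. Compound 2 `CCn1cc(-c2nc3ccc(Cl)cc3[nH]2)c(=O)c2cc(F)c(N3CCNCC3)cc21` gives 2800 nM in this assay, and compound 3 `CCn1cc(-c2nc3ccc([N+](=O)[O-])cc3[nH]2)c(=O)c2cc(F)c(N3CCNCC3)cc21` gives 2100 nM. The difference between the core of compound 1 and the core of compound 2 is not broken down here; the two values show that compound 1 stands well beyond the scatter from both compound 2 and compound 3.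

Within the core of compound 2, the change nitro in place of chloro on an aromatic carbon produced the step of a 1.3-fold lower number from compound 2 to compound 3 (0.12 log units; within the scatter). Compound 4 `CCn1cc(-c2nc3ccc([N+](=O)[O-])cc3[nH]2)c(=O)c2cc(F)c(N3CCNCC3)nc21`, not yet measured, carries the same change on the core of compound 1: nitro in place of chloro on an aromatic carbon. The place of the change is the same in both pairs.

Because the measured step of a 1.3-fold lower number from compound 2 to compound 3 (0.12 log units; within the scatter) lies within the scatter, compound 4 is expected to stand close to compound 1, with an estimated step of a 1.3-fold lower number from compound 1 to compound 4 (0.11 log units; within the scatter). The estimate for compound 4 in this assay is 16500 nM, with a range from 6000 nM to 45000 nM reflecting the uncertainty of carrying one step from one core to another.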

Compound 4, half-maximal inhibitory concentration: 10800 nM
The estimate for compound 4 lay 1.5-fold (0.18 log units) above the measured number; measured number inside the range.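

In this assay, nitro in place of chloro on the core of compound 1 gives a 2.0-fold lower number from compound 1 to compound 4 (0.30 log units; within the scatter), a step that cannot be told apart from repeated measurement. Set beside the same change on the core of compound 2, the new step does not differ from the earlier one: the same change on two cores in this assay, a 1.3-fold lower number (0.12 log units; within the scatter) from compound 2 to compound 3 and a 2.0-fold lower number (0.30 log units; within the scatter) from compound 1 to compound 4, 1.5-fold (0.17 log units) apart, within the scatter of two such steps. This shows that, for these two pairs, the change behaves alike on both cores and leaves each number within the scatter of its chloro partner, but it does not show that nitro differs from chloro on either core, and with one pair per core and a single cell assay it cannot support a general rule for the series.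

The compounds shown leave open what other groups on this aromatic carbon would do, such as an amine, a carboxylic acid or a methoxy group. They also leave open whether any such group would give a step beyond the scatter on either core, and whether that step would then carry from one core to the other.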